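The compounds below may be only part of what the source reports. "The series", "measured", "known", "first", "only" and "open" are said of these compounds alone.

Of the compounds shown here, three built on a shared core have been tested in a functional assay (Cavia porcellus) with sulfonylurea receptors; K-ATP channels (Homo sapiens) as the target; a lower number here means a stronger inhibitor, a higher number a weaker inhibitor. Compound 1 `CC(O)(C(=O)Nc1cccc(S(=O)(=O)c2ccccc2)c1)C(F)(F)F` returns in this assay only a limit, > 30000 nM, and no number. Compound 2 `CC(O)(C(=O)Nc1ccc(C#N)c(Sc2ccccc2)c1)C(F)(F)F` gives a measured value in this assay of 8300 nM. Compound 3 `CC(O)(C(=O)Nc1ccc(S(=O)(=O)c2ccc(C#N)cc2)cc1)C(F)(F)F` again yields only a limit in this assay, > 30000 nM, so its true potency is not known as a number. Compound 3 therefore stands at the limit of > 30000 nM in this assay, at which 2 of the 3 values shown sit, together with most of what has been measured here. Compound 4 `Cc1ccccc1S(=O)(=O)c1ccc(NC(=O)C(C)(O)C(F)(F)F)cc1` has not yet been tested. It differs from compound 3 in one place: 2-methylphenyl in place of 4-cyanophenyl on a sulfonyl sulfur. Going by the values given here, no measured pair of compounds differs in just this way, so the size of this step cannot be read from the data, and a limit as the starting point leaves it doubly open. The step of a number no higher from compound 3 to compound 4 (the limit leaves the size open) is expected to stay within the scatter, with no clear direction. Compound 4 is estimated to sit at 30000 nM, with a range from 8000 nM to 100000 nM, and it is expected that the assay may again report only a limit for compound 4 rather than a number.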

Compound 4, half-maximal inhibitory concentration: 5100 nM
Estimate against measurement, compound 4: 5.9-fold (0.77 log units) above; the whole stated range lies above it.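

In this assay, putting 2-methylphenyl in place of 4-cyanophenyl on a sulfonyl sulfur brings an at least 5.8-fold lower number from compound 3 to compound 4 (0.76 log units; beyond the scatter), so the result at this position depends on the group it carries. This is the first step between measured compounds that differ in one place, and compound 4 is the first compound shown with a sulfonyl group to return a number rather than a limit. The true size of the step remains unknown, and the printed figure is only a minimum, as its starting point, compound 3, stands at a limit: the limit of > 30000 nM in this assay, at which 2 of the 4 values shown sit.

Going by these compounds, the two parts of this change arrive together in one step, so it remains open whether the lower number goes with the methyl group that enters, with the nitrile that leaves, or with both. Also open, on these data alone, is how a pyridine ring or a simple ethyl chain on the same sulfonyl sulfur would read in this assay, and whether any such group would give a lower number than compound 4 does.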